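Chloro position on the pyridinyl amide of compound 2

The source may hold more compounds than are shown below. What is called first, only, known or untested is meant among the compounds shown, and "the series" means these compounds.

Measured compounds:
compound 1 `CCCNC(=O)c1ccc(Oc2nc(-c3c(C)noc3C)cnc2N)cc1` 6880 nM
compound 2 `Cc1noc(C)c1-c1cnc(N)c(Oc2ccc(C(=O)Nc3cccc(Cl)n3)cc2)n1` 35700 nM

For the measured compounds named here, in a functional assay on HepG2 cells (Homo sapiens) for inhibition, read by MTT assay, with a stated time of 72 h (a higher number here means a weaker inhibitor, a lower number a stronger inhibitor), compound 2 gives 35700 nM, the highest of the two numbers so far; its nearest neighbour is compound 1, reached by a 5.2-fold higher number from compound 1 to compound 2 (0.72 log units; beyond the scatter). Compound 3 `Cc1noc(C)c1-c1cnc(N)c(Oc2ccc(C(=O)Nc3cc(Cl)ccn3)cc2)n1` differs from compound 2 only in 4-chloropyridin-2-yl in place of 6-chloropyridin-2-yl on an amide-type nitrogen. Going by the values given here, no measured step touches this change; the single step known, from a propyl to a chloropyridinyl group, says nothing about where the chlorine sits on that ring. No step beyond the scatter is therefore expected, and a 1.2-fold lower number from compound 2 to compound 3 (0.08 log units; within the scatter) is the estimate. Compound 3 is expected at 30000 nM, within 10000 nM to 100000 nM.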

Compound 3, half-maximal inhibitory concentration: > 100000 nM
Compound 3 gave a limit, no number; the forecaster's own chance of this, stated with the estimate: 15%; middle value at least 3.3-fold (0.52 log units) away from the limit.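

With the atoms unchanged, 4-chloropyridin-2-yl in place of 6-chloropyridin-2-yl on the amide nitrogen gives an at least 2.8-fold higher number from compound 2 to compound 3 (0.44 log units; beyond the scatter) in this assay, so the place of the chlorine on this ring alone moves the result. Set against the propyl amide, the same group gives an at least 14-fold higher number from compound 1 to compound 3 (1.16 log units; beyond the scatter). The reading for compound 3 is a limit of the assay, not a number: the limit of > 100000 nM in this assay, at which 1 of the 3 values shown sits.

Going by these compounds, how far compound 3 lies past that limit stays open, and with it the full size of both steps. Also open, on these data alone, is whether a methoxy group or an amine in place of the chlorine would give a readable number.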